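Compound 3 and the undefined stereocentre of compound 2

The source may report more compounds than this note shows. Statements on the series, on what has been measured and on what is new or still open speak of the compounds shown alone.

Measured in a functional assay on BGC-823 cells (Homo sapiens) for cytotoxicity, read by MTT assay, with a stated time of 48 h; a lower number here means a stronger inhibitor, a higher number a weaker inhibitor:
- compound 1 `C=C(C(=O)c1cc(OC)c(O)c(OC)c1)[C@H](CO)C(=O)c1cc(OC)c(O)c(OC)c1`: > 100 ug/mL, a limit of the assay
- compound 2 `C=C(C(=O)c1cc(OC)c(O)c(OC)c1)C(CO)C(=O)c1cc(OC)c(O)c(OC)c1`: 58.9 ug/mL

Among the measured compounds shown here, compound 2, at 58.9 ug/mL, holds the only actual number so far. The result for compound 1 is a limit. Compound 3 `C=C(C(=O)c1cc(OC)c(O)c(OC)c1)[C@@H](CO)C(=O)c1cc(OC)c(O)c(OC)c1` differs from compound 2 as follows: the two compounds have the same atoms and bonds; at least one stereo element is drawn with a configuration in one of them and without one in the other: 1 of 1 stereo elements differ; a stereocentre at a saturated chain carbon is drawn without a configuration in compound 2 and S in compound 3. For the measured compounds named here, one measured step bears on this change: an at least 1.6-fold lower number from compound 1 to compound 2 (0.22 log units; that floor lies within the scatter). That step concerns (the fact that one of compounds 1 and 2 is drawn with a defined configuration and the other without, at the place where they differ), and its size rests on (the limit of > 100 ug/mL in this assay, at which 1 of the 2 values shown sits). Given an at least 1.6-fold lower number from compound 1 to compound 2 (0.22 log units; that floor lies within the scatter), a modest move towards a lower number is expected in this assay. The expected step is a 1.7-fold lower number from compound 2 to compound 3 (0.23 log units; within the scatter). For compound 3 the estimated value is 35 ug/mL, with an expected range of 15 ug/mL to 80 ug/mL.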

Compound 3, half-maximal inhibitory concentration: 45.5 ug/mL
Compound 3: the middle estimate sits 1.3-fold (0.11 log units) below what was measured, and the stated range covers the measured number.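

In this assay, the change from R to S at this saturated chain carbon brings an at least 2.1-fold lower number from compound 1 to compound 3 (0.34 log units; beyond the scatter), the first step at this stereocentre to pass beyond the scatter, with nothing else altered: the fact that compounds 1 and 3 differ only in the configuration as drawn The result for compound 1 is a limit of the assay, so this size is only a floor: the limit of > 100 ug/mL in this assay, at which 1 of the 3 values shown sits. By contrast, a 1.3-fold lower number from compound 2 to compound 3 (0.11 log units; within the scatter) does not separate the S form from the undefined drawing: the fact that one of compounds 2 and 3 is drawn with a defined configuration and the other without, at the place where they differ

Going by these compounds, how large the gap between the R and S forms really is stays open. So does whether the S form keeps its lower number with an amine or a carboxylic acid on this chain.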